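The source may report more compounds than this note shows. Statements on the series, on what has been measured and on what is new or still open speak of the compounds shown alone.

Measured so far:
Compound 1, `O=C(NCc1ccc(S(=O)(=O)c2cc(F)cc(F)c2)cc1)c1cc2ccncc2o1`, gives 14 nM in an assay for inhibition of Nicotinamide phosphoribosyltransferase (Homo sapiens), read by mass spectrometry, with stated times of 15 min and 30 min; on this read-out lower numbers stand for stronger inhibition and higher numbers for weaker inhibition.
Compound 2, `O=C(NCc1ccc(S(=O)(=O)c2ccccc2)cc1)c1nc2cnccc2[nH]1`, gives 7100 nM in this assay.

Compound 2 stands at the higher of the two numbers, far apart from compound 1, which is the weaker inhibitor of the pair. Compound 3, `O=C(NCc1ccc(S(=O)(=O)c2ccccc2)cc1)c1cnc2nccn2c1`, has not been measured. It differs from compound 2 on a carbonyl carbon: a group of 9 heavy atoms (6 carbon, 3 nitrogen; one five-membered aromatic ring with 2 hetero atoms, one six-membered aromatic ring with 2 hetero atoms) in place of a group of 9 heavy atoms (6 carbon, 3 nitrogen; one five-membered aromatic ring with 2 hetero atoms, one six-membered aromatic ring with 1 hetero atom), on a carbonyl carbon. For the measured compounds named here, no measured pair shows this change, so its effect is unknown; a modest move toward a lower number is expected, though one within the scatter cannot be ruled out. Compound 3 is expected to give about 2000 nM, likely between 300 nM and 12000 nM. The expected step is a 3.6-fold lower number from compound 2 to compound 3 (0.55 log units; beyond the scatter).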

Compound 3, half-maximal inhibitory concentration: 2 nM
Compound 3: middle estimate off by 1000-fold (3.00 log units), on the high side; the measured number lies below the stated range.
By their numbers in this assay, from the lowest: compound 3; then compound 1; then compound 2.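

Swapping one group on a carbonyl carbon gives a 3600-fold lower number from compound 2 to compound 3 (3.55 log units; beyond the scatter) in this assay even though both groups hold the same atoms, joined differently. So at this place, the arrangement of atoms alone can decide the result. The group that enters has 0 hydrogen-bond donors and 3 acceptors where the group that leaves has 1 and 2, but nothing shown explains the step. The compounds leave open which feature of the entering group matters, and whether a methyl group or an amine attached to it would keep the number low.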